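Enaminone series: methoxy for chloro on the aniline

The source may hold more compounds than are shown below. What is called first, only, known or untested is meant among the compounds shown, and "the series" means these compounds.

compound 1 `COc1ccc(N/C=C\C(=O)c2nc(-c3ccc(OC)cc3)n3ccccc23)cc1` — 2120 nM
compound 2 `O=C(/C=C\Nc1ccc2[nH]ccc2c1)c1nc(-c2ccc(C(F)(F)F)cc2)n2ccccc12` — 18200 nM
compound 3 `O=C(/C=C\Nc1ccc(Cl)cc1)c1nc(-c2ccc(C(F)(F)F)cc2)n2ccccc12` — > 30000 nM

In a functional assay on B16-F10 cells (Mus musculus) for cytotoxicity, read by MTT assay, with a stated time of 48 h (a higher number here means a weaker inhibitor, a lower number a stronger inhibitor), compound 1 gives 2120 nM and compound 2 gives 18200 nM. For compound 3 the assay reports only a limit, > 30000 nM, so compound 3 stands at the limit of > 30000 nM in this assay, at which 1 of the 3 values shown sits, and is the weakest point among the numbers shown, with no exact value. Among the measured compounds shown here, the only measured step that reaches it is an at least 1.6-fold higher number from compound 2 to compound 3 (0.21 log units; that floor lies within the scatter), which sits within the scatter at its floor.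

Compound 4 `COc1ccc(N/C=C\C(=O)c2nc(-c3ccc(C(F)(F)F)cc3)n3ccccc23)cc1` differs from compound 3 by methoxy in place of chloro on an aromatic carbon. For the measured compounds named here, no measured pair makes this exact exchange. The nearest reference is compound 1, which carries the same methoxyphenyl amine and gives 2120 nM. The trifluoromethylphenyl of compound 4 is shared by compound 2, which gives 18200 nM. A lower number is therefore expected for compound 4, as the step of an at least 3.3-fold lower number from compound 3 to compound 4 (0.52 log units; beyond the scatter), though a limit cannot be excluded. The estimate for compound 4 is 9000 nM, with a range from 2500 nM to 30000 nM.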

Compound 4, half-maximal inhibitory concentration: > 30000 nM
Compound 4: only a limit was reported (the forecaster's own chance of this, stated with the estimate: 25%); at least 3.3-fold (0.52 log units) between middle value and limit.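

In this assay, compound 4 reports only a limit, and the steps that the two limits leave unreadable cannot be read, so methoxy and chloro on this aromatic carbon cannot be ranked here: the limit of > 30000 nM in this assay, at which 2 of the 4 values shown sit. With the 4-methoxyphenyl amine held in place, trifluoromethyl in place of methoxy gives an at least 14-fold higher number from compound 1 to compound 4 (1.15 log units; beyond the scatter), so this amine alone does not keep the lower number of the series. Exchanging 1H-indol-5-yl for 4-methoxyphenyl on the amine nitrogen gives an at least 1.6-fold higher number from compound 2 to compound 4 (0.21 log units; that floor lies within the scatter), which leaves these two amines unseparated at the floor of the step.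

As far as these compounds go, whether chloro on the amine side would differ from methoxy alongside the methoxyphenyl of compound 1 stays open. Also open, from the compounds shown here alone, is whether an amine or a carboxylic acid in place of trifluoromethyl would shift the number.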